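Compound 2 and its 6-methoxypyridin-3-yl counterpart, compound 4

The source may hold more compounds than are shown below. What is called first, only, known or untested is meant among the compounds shown, and "the series" means these compounds.

In a functional assay on MCF7 cells (Homo sapiens) for antiproliferative activity, read by MTT assay, with a stated time of 72 h (on this read-out lower numbers stand for stronger inhibition and higher numbers for weaker inhibition), compound 1 `C=CC(=O)Nc1cccc(Oc2nc(Nc3cccc(OC)c3)nc3c2CSCC3)c1` gives > 50000 nM, which is a limit of the assay and not a number. Compound 2 `CCC/C=C/C(=O)Nc1cccc(Oc2nc(Nc3cccc(OC)c3)nc3c2CSCC3)c1` gives 32000 nM and compound 3 `COc1cccc(Nc2nc3c(c(Oc4cccc(NC(=O)/C=C/C(C)C)c4)n2)CSCC3)c1` gives 21800 nM, two values within the scatter of each other. Compound 4 `CCC/C=C/C(=O)Nc1cccc(Oc2nc(Nc3ccc(OC)nc3)nc3c2CSCC3)c1` has 6-methoxypyridin-3-yl in place of 3-methoxyphenyl on a nitrogen on an aromatic ring.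

The measured steps are an at least 1.5-fold lower number from compound 1 to compound 2 (0.19 log units; that floor lies within the scatter), an at least 2.2-fold lower number from compound 1 to compound 3 (0.36 log units; beyond the scatter) and a 1.5-fold lower number from compound 2 to compound 3 (0.17 log units; within the scatter). All three alter the group on the carbonyl carbon, and none alters the 3-methoxyphenyl group, so they bear on this change only indirectly and give no direction for it. The best anchor is compound 2 at 32000 nM. In this assay, no shift beyond the scatter is therefore expected, and the estimated change is a 1.1-fold lower number from compound 2 to compound 4 (0.03 log units; within the scatter). Compound 4 is expected at 30000 nM, with an estimated range of 14000 nM to 60000 nM.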

Compound 4, half-maximal inhibitory concentration: 26800 nM
The estimate for compound 4 lay 1.1-fold (0.05 log units) above the measured number; the measured number falls inside the stated range.
By their numbers in this assay, from the lowest: compounds 3, 4 and 2 (each within the scatter of the next). At a limit, above all of these: compound 1.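

Within the data shown here, the earlier compounds varied only the group on the carbonyl carbon, so this is the first reading at the nitrogen on an aromatic ring. In this assay, 6-methoxypyridin-3-yl in place of 3-methoxyphenyl gives a 1.2-fold lower number from compound 2 to compound 4 (0.08 log units; within the scatter), so an extra hydrogen-bond acceptor by count, with a ring nitrogen entering, leaves the two compounds indistinguishable here while the pent-1-en-1-yl group stays fixed. Compound 1 alone stands at a limit of the assay, which is not a number: the limit of > 50000 nM in this assay, at which 1 of the 4 values shown sits.

From the compounds shown here alone, it remains open whether this position would read differently with a ring carrying an amine or a carboxylic acid instead of the methoxy group. Going by these compounds, it is also open whether the same exchange would read alike with the 3-methylbut-1-en-1-yl group of compound 3.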